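A further methoxy group on compound 3

This account rests on a few compounds, and the source may have more. Where it says the series, first, only, none or still open, it means among the compounds named here.

Measured in a physicochemical assay, read by spectrophotometry, with a stated time of 15 min; a higher number here means a weaker inhibitor, a lower number a stronger inhibitor:
Compound 1 `O=C(CCc1nc2ccccc2c(=O)[nH]1)N/N=C/c1ccc(O)c(O)c1` gives 105000000 nM
Compound 2 `COc1cc(/C=N/NC(=O)CCc2nc3ccccc3c(=O)[nH]2)cc(OC)c1OC` gives 80000000 nM
Compound 3 `COc1cc(/C=N/NC(=O)CCc2nc3ccccc3c(=O)[nH]2)ccc1O` gives 290000000 nM

Compound 3 has the highest number of the three, and its gaps to compound 1 and compound 2 both lie beyond the scatter. Compound 4 `COc1cc(/C=N/NC(=O)CCc2nc3ccccc3c(=O)[nH]2)cc(OC)c1O` differs from it by one change: methoxy in place of hydrogen on an aromatic carbon, ortho to a hydroxy group.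

For the measured compounds named here, only one measured step bears on this, and only indirectly. It is a 2.8-fold higher number from compound 1 to compound 3 (0.44 log units; beyond the scatter), with methyl in place of hydrogen on an oxygen on an aromatic ring. That step is modest and is a different change, so it indicates only the size that a small change on this ring has produced. Going by the values given here, no measured step adds methoxy to an aromatic carbon. Among the compounds with values here, compound 2, the only measured compound with further methoxy groups on that ring, gives 80000000 nM, a lower number than that of compound 3.

A modest move to a lower number is therefore expected, with an estimated 2.2-fold lower number from compound 3 to compound 4 (0.35 log units; beyond the scatter) in this assay. For compound 4 the expected value is 130000000 nM, within an estimated range from 55000000 nM to 300000000 nM.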

Compound 4, half-maximal inhibitory concentration: 275000000 nM
Compound 4: the middle estimate sits 2.1-fold (0.33 log units) below what was measured, within the range that was stated.
By their numbers in this assay, from the lowest: compounds 2 and 1 (each within the scatter of the next); then compounds 4 and 3 (each within the scatter of the next).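

In this assay, methoxy in place of hydrogen on an aromatic carbon, ortho to a hydroxy group, gives a 1.1-fold lower number from compound 3 to compound 4 (0.02 log units; within the scatter), so this position tolerates the added group with no resolvable shift in the number. The methyl on an oxygen on the ring does show a resolvable effect, and its direction differs between pairs: removing it gives a 3.4-fold higher number from compound 2 to compound 4 (0.54 log units; beyond the scatter), while adding it gives a 2.8-fold higher number from compound 1 to compound 3 (0.44 log units; beyond the scatter), so the same kind of change raises the number in one pair and lowers it in the other, and its outcome cannot be carried from one pair to the next. Nothing available accounts for the flat result at the carbon or for the opposite directions at the oxygen.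

The compounds shown leave open whether a different group at this carbon, such as an amine or a chlorine atom, would also leave the number unresolved from that of compound 3. They also leave open whether methoxy here would behave the same way with a longer chain on the oxygen of the hydroxy group, or with that hydroxy group replaced by a carboxylic acid.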